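Halogen swap on the aryl ketone of a chalcone-type pyrazole

This account rests on a few compounds, and the source may have more. Where it says the series, first, only, none or still open, it means among the compounds named here.

Three compounds sharing a core of a pyrazole linked through an unsaturated ketone to an aryl group have been examined in a functional assay on MDA-MB-435 cells (Homo sapiens) for cytotoxicity, read by sulforhodamine B assay, with a stated time of 48 h, tested at 1 uM; on this read-out higher numbers stand for a weaker effect at the one concentration tested and lower numbers for a stronger effect. Compound 1 `COc1cc(-c2cc(/C=C/C(=O)c3ccc(Cl)c(Cl)c3)[nH]n2)cc(OC)c1OC` gives 90% in this assay, the highest of the three numbers. Compound 2 `COc1ccc(-c2cc(/C=C/C(=O)c3ccc(N)cc3)[nH]n2)cc1` gives 85% in this assay, which lies within the scatter of compound 1. Compound 3 `COc1cc(C(=O)/C=C/c2cc(-c3cc(OC)c(OC)c(OC)c3)n[nH]2)cc(OC)c1OC` gives 79% in this assay, a number that sits beyond the scatter below compound 1, so only compound 3 stands apart from it among these three.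

Compound 4 `COc1cc(-c2cc(/C=C/C(=O)c3ccc(F)c(F)c3)[nH]n2)cc(OC)c1OC` has not yet been measured. It differs from compound 1 in one place: 3,4-difluorophenyl in place of 3,4-dichlorophenyl on a carbonyl carbon. The rest of the molecule, the trimethoxyphenyl on the pyrazole and the unsaturated ketone, is unchanged.

Going by the values given here, no pair of measured compounds differing in a single place is available, so there is no measured step on which to rest a direction for this halogen exchange. Given that compound 1 gives 90%, the step of a number 2 percentage points lower from compound 1 to compound 4 (within the scatter) is expected to be small and not beyond the scatter. Compound 4 is therefore estimated to give 88% in this assay, with a range from 74% to 100%.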

Compound 4, a percentage reported as activity, at one concentration (the size of the read-out at that concentration, not a potency): 88%
Beside the measured number, compound 4's estimate shows no gap at the digits printed; the measured number falls inside the stated range.
By their numbers in this assay, from the lowest: compounds 3, 2, 4 and 1 (each within the scatter of the next, the first and the last beyond it).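

The exchange of 3,4-dichlorophenyl for 3,4-difluorophenyl on a carbonyl carbon reads in this assay as a number 2 percentage points lower from compound 1 to compound 4 (within the scatter) and gives this set its first measured change in a single place. At the one concentration tested, this place therefore accepts one of these two dihalogenated phenyl groups for the other with no change beyond the scatter, while the trimethoxyphenyl on the pyrazole and the unsaturated ketone stay as they were. No measurement accompanies this result that could say what lies behind so small a step.

This single exchange keeps both halogens on the same ring and so cannot tell whether the number would hold with a different kind of group on the carbonyl carbon, such as an unsubstituted phenyl, a pyridine ring or a phenyl carrying a carboxylic acid. It also leaves open whether compound 1 and compound 4 would stay within the scatter of each other at another concentration or on another cell line.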